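Removing both chlorines from the anilino ring of compound 3

The source may report more compounds than this note shows. Statements on the series, on what has been measured and on what is new or still open speak of the compounds shown alone.

Compound 3, `COc1cc(/C=C/C(=O)c2sc(Nc3ccc(Cl)c(Cl)c3)nc2C)cc(OC)c1OC`, carries a 3,4-dichlorophenyl on the ring nitrogen. In a functional assay on Bel-7402 cells (Homo sapiens) for cytotoxicity, read by MTT assay (on this read-out higher numbers stand for weaker inhibition and lower numbers for stronger inhibition), compound 3 reaches only a limit of the assay, > 25000 nM. Compound 1, `COc1cc(/C=C/C(=O)c2sc(Nc3ccc(Cl)cc3)nc2C)cc(OC)c1OC`, also sits at a limit in this assay, > 25000 nM. Among the compounds with values here, compound 2, `COc1cc(/C=C/C(=O)c2sc(Nc3cccc(Cl)c3)nc2C)cc(OC)c1OC`, is the one member of the series with a measured number, giving 14000 nM in this assay. Two of the three values sit at the limit of > 25000 nM in this assay, at which 2 of the 3 values shown sit, so compound 3 cannot be placed relative to compound 1, and its step to compound 2 is readable only as a floor.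

Compound 4, `COc1cc(/C=C/C(=O)c2sc(Nc3ccccc3)nc2C)cc(OC)c1OC`, differs from compound 3 by phenyl in place of 3,4-dichlorophenyl on a nitrogen on an aromatic ring. Of the measured steps, an at least 1.7-fold higher number from compound 2 to compound 3 (0.25 log units; that floor lies within the scatter) bears on it most directly, as it removes one of the two chlorines that the present change removes; a step that the two limits leave unreadable from compound 1 to compound 3 adds nothing readable, and an at least 1.7-fold lower number from compound 1 to compound 2 (0.25 log units; that floor lies within the scatter) only shows that moving a single chlorine changes little beyond the scatter. The evidence is therefore thin and bounded by limits. The step of an at least 1.3-fold lower number from compound 3 to compound 4 (0.14 log units; that floor lies within the scatter) is expected to be small and, if anything, toward a lower number. Compound 4 is accordingly estimated at 18000 nM in this assay, with a range from 7000 nM to 50000 nM, and a real chance that only a limit is again returned.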

Compound 4, half-maximal inhibitory concentration: > 25000 nM
Compound 4: a limit, no number; the forecaster's own chance of this, stated with the estimate: 45%; middle value at least 1.3-fold (0.14 log units) from the limit.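

In this assay, the plain phenyl on the nitrogen brings no readable gain over the chlorinated rings: compound 4 returns > 25000 nM, which is a limit and not a number. The one readable new step is an at least 1.7-fold higher number from compound 2 to compound 4 (0.25 log units; that floor lies within the scatter), so hydrogen in place of chloro on an aromatic carbon is not shown to do more here than repeat measurements would. The steps to compound 4 from compound 1 and from compound 3 cannot be read, and with the chlorine-free ring now also at the limit, only compound 2 goes against the series sitting there: the limit of > 25000 nM in this assay, at which 3 of the 4 values shown sit.

Open is whether any group on this ring can bring the series to values well clear of the limit, since the ring substituents shown are only chloro and hydrogen. A dimethylamino group or a carboxylic acid in place of the chloro would test this, and a number rather than a limit would be needed before any ranking of these anilino rings could be made.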